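The source may report more compounds than this note shows. Statements on the series, on what has been measured and on what is new or still open speak of the compounds shown alone.

In a functional assay on MKN-45 cells (Homo sapiens) for cytotoxicity, read by MTT assay, with a stated time of 72 h (a higher number here means a weaker inhibitor, a lower number a stronger inhibitor), compound 3 `COc1cc2c(Oc3ccc(NC(=O)c4nn(-c5ccc(F)cc5)c(=O)c5ccccc45)cc3F)ccnc2cc1OCCCN1CCN(C)CC1` gives 150 nM, the lowest of the three numbers shown. Its nearest neighbour is compound 1 `COc1cc2c(Oc3ccc(NC(=O)c4nn(-c5ccc(Br)cc5)c(=O)c5ccccc45)cc3F)ccnc2cc1OCCCN1CCCC1`, which gives 230 nM, a gap within the scatter; the furthest is compound 2 `COc1cc2c(Oc3ccc(NC(=O)c4nn(-c5ccc([N+](=O)[O-])cc5)c(=O)c5ccccc45)cc3F)ccnc2cc1OCCCN1CCCC1`, which gives 1620 nM, a gap beyond the scatter. Compound 4 `COc1cc2c(Oc3ccc(NC(=O)c4nn(-c5ccc([N+](=O)[O-])cc5)c(=O)c5ccccc45)cc3F)ccnc2cc1OCCCN1CCN(C)CC1` differs from compound 3 in one place: nitro in place of fluoro on an aromatic carbon. Among the compounds with values here, one measured step bears on this change. Compound 1 and compound 2 share the core of compound 3 but differ from it in the chain, and between them a halogen on an aromatic carbon gives way to nitro, just as here; that step reads a 7.0-fold higher number from compound 1 to compound 2 (0.85 log units; beyond the scatter). Since a halogen is again exchanged for nitro, the change in compound 4 is expected to behave much like that step, with a higher number in this assay, beyond the scatter. The expected step is a 6.0-fold higher number from compound 3 to compound 4 (0.78 log units; beyond the scatter). Compound 4 is therefore expected to give 900 nM, with a range from 350 nM to 2500 nM.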

Compound 4, half-maximal inhibitory concentration: 1320 nM
For compound 4 the middle estimate is 1.5-fold (0.17 log units) below the measured one; the measured number falls inside the stated range.
By their numbers in this assay, from the lowest: compounds 3 and 1 (each within the scatter of the next); then compounds 4 and 2 (each within the scatter of the next).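

In this assay, the step of an 8.8-fold higher number from compound 3 to compound 4 (0.94 log units; beyond the scatter) shows that nitro in place of fluoro, para to a large group, carries a cost beyond the scatter, as nitro in place of bromo did in the step of a 7.0-fold higher number from compound 1 to compound 2 (0.85 log units; beyond the scatter) on the other chain, so the pattern holds in both listed pairs. With nitro in place, 4-methylpiperazin-1-yl and pyrrolidin-1-yl at the chain end cannot be told apart, as the step of a 1.2-fold lower number from compound 2 to compound 4 (0.09 log units; within the scatter) lies within the scatter. No accompanying measurement offers an explanation for either nitro step.

From the compounds shown here alone, how an amine or a nitrile at this ring position would compare with fluoro and nitro remains open. Whether the two chain ends also match with a halogen on the ring is open too, as compound 1 and compound 3 differ in two places.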